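From amino to sulfoamino on compound 1

The source may hold more compounds than are shown below. What is called first, only, known or untested is meant among the compounds shown, and "the series" means these compounds.

In a physicochemical assay for lipophilicity, at pH 7.4 (a higher number here means a more lipophilic compound, a lower number a more polar compound), compound 1 `Nc1ccc(-c2nc3ccccc3s2)cc1I` stands only at a limit, > 2.7. Compound 2 `O=S(=O)(O)Nc1ccc(-c2nc3ccccc3s2)cc1Cl`, which also carries sulfoamino, is likewise reported only as a limit, < 2.19. Compound 3 `O=S(=O)(O)Nc1ccc(-c2nc3ccccc3s2)cc1I` derives from compound 1 by placing sulfo in place of hydrogen on a nitrogen on an aromatic ring. A downward step beyond the scatter is expected in this assay, a reading that rests on the limit of compound 2, < 2.19. The estimated step is a number at least 0.80 log units lower from compound 1 to compound 3 (beyond the scatter). Compound 3 is thus expected at 1.9, with an estimated range from 1.1 to 2.5.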

Compound 3, distribution coefficient: 1.9
Compound 3: middle estimate and measured number agree at the digits printed; measured number inside the range.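

Going by these compounds alone, with compound 3, sulfo in place of hydrogen on a nitrogen on an aromatic ring gives the first single-place comparison at this position in this assay: a number at least 0.80 log units lower from compound 1 to compound 3 (beyond the scatter). It also gives the first number rather than a limit for a compound carrying sulfoamino. The step has no fixed size, only a lower bound on its extent: the limit of > 2.7 in this assay, at which 1 of the 3 values shown sits.

The step between compound 2 and compound 3, iodo in place of chloro, cannot be read. As far as these compounds go, whether a carboxylic acid in place of sulfo on this nitrogen would give a step of similar size also stays open.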